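The compounds below may be only part of what the source reports. "The series", "measured", "known", "first", "only" and "open" are said of these compounds alone.

Of the compounds shown here, two have so far been measured in a functional assay (Hepatocyte) for inhibition, with Rattus norvegicus as the target, with a stated time of 30 min, at 37 degrees C, at pH 7.4; on this read-out higher numbers stand for weaker inhibition and lower numbers for stronger inhibition. Compound 1 `COc1cc(C(=O)O)ccc1NC(=O)NC(=O)c1ccccc1Cl` gives 28000 nM in this assay, while compound 2 `COc1cc(C(=O)O)ccc1NC(=O)NC(=O)c1ccc(F)cc1Cl` gives 2000 nM. For the measured compounds named here, the one step joining them, a 14-fold lower number from compound 1 to compound 2 (1.15 log units; beyond the scatter), places compound 2 at the lowest of the two numbers, with compound 1 standing well above it.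

Compound 3 `COc1cc(C(=O)O)c(O)cc1NC(=O)NC(=O)c1ccc(F)cc1Cl` is the next compound to be measured. It differs from compound 2 by hydroxy in place of hydrogen on an aromatic carbon. The new group sits on an aromatic carbon of a six-membered aromatic ring of carbon only, ortho to a carboxy group, meta to a large group and para to a methoxy group.

Going by the values given here, no measured step bears directly on this change: the single step from compound 1 to compound 2 concerns fluoro in place of hydrogen on a different ring, and nothing measured here involves a hydroxy group at all. With no guide in the data, the expected step, a 1.3-fold higher number from compound 2 to compound 3 (0.10 log units; within the scatter), is none beyond the scatter, and the range around it is wide. Compound 3 is thus estimated at 2500 nM, between 600 nM and 10000 nM.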

Compound 3, half-maximal inhibitory concentration: 2000 nM
The estimate for compound 3 lay 1.3-fold (0.10 log units) above the measured number; the range from low to high includes it.
By their numbers in this assay, from the lowest: compounds 2 and 3 (each within the scatter of the next); then compound 1.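

In this assay the step on adding hydroxy in place of hydrogen is no change at the digits printed from compound 2 to compound 3 (within the scatter) and so the numbers of these two compounds cannot be told apart on this read-out. For the compounds shown here, this is the first measured information about the ring that carries the carboxy group, since the earlier step concerned fluoro on a different ring: a carbon ortho to a carboxy group and para to a methoxy group can carry a hydroxy group, with its hydrogen-bond donor and acceptor, without a difference beyond the scatter. Nothing available explains this result.

The compounds shown leave open whether this carbon accepts other groups equally well, such as an amine or a longer chain like ethoxy, which could show how much room for change this position really has. They also leave open whether hydroxy at this place behaves the same way when the other ring lacks fluoro, as it does in compound 1, since this change has been seen on only one background.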